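Replacing 3-fluoroprop-1-en-1-yl with 1-fluoroethenyl

This account rests on a few compounds, and the source may have more. Where it says the series, first, only, none or still open, it means among the compounds named here.

In an ADME assay for pharmacokinetics, read by LC-MS, in phosphate buffer, with a stated time of 120 min, at pH 7.4, tested at 1 uM, in the presence of a further agent that is not named here (on this read-out lower numbers stand for a shorter-lived compound and higher numbers for a longer-lived compound), compound 1 (`O=C(/C=C/CF)Nc1ccccc1`) gives > 8.53 h as a limit and not a number. In the same assay compound 2 (`O=C(/C=C/C(F)F)Nc1ccccc1`) gives 0.733 h as a true number. Compound 3 (`C=C(F)C(=O)Nc1ccccc1`) departs from compound 1 by 1-fluoroethenyl in place of 3-fluoroprop-1-en-1-yl on a carbonyl carbon on the carbonyl carbon. Going by the values given here, the only measured guide is an at least 11-fold lower number from compound 1 to compound 2 (1.06 log units; beyond the scatter) and it bears only indirectly, as a change within the chain. A large downward change is expected, estimated as an at least 4.2-fold lower number from compound 1 to compound 3 (0.62 log units; beyond the scatter) with wide uncertainty. For compound 3 the estimated half-life is 2 h with an expected range from 0.4 h to 9 h on this reading.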

Compound 3, half-life: > 8.53 h
Compound 3: no number, only a limit; the forecaster's own chance of this, stated with the estimate: 15%; middle value at least 4.2-fold (0.62 log units) away from the limit.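

The step from compound 1 to compound 3 cannot be read, as both compounds give only a limit in this assay: the limit of > 8.53 h in this assay, at which 2 of the 3 values shown sit.

From the compounds shown here alone, whether 1-fluoroethenyl in place of 3-fluoroprop-1-en-1-yl changes the half-life at all, and by how much, stays open.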